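The source may report more compounds than this note shows. Statements on the series, on what has been measured and on what is new or still open speak of the compounds shown alone.

Going by the values given here, in an ADME assay on HEK293 cells (Homo sapiens) for cytotoxicity, read by MTT assay, with a stated time of 48 h (a higher number here means a weaker inhibitor, a lower number a stronger inhibitor), compound 3 `CN(C)CCCn1c(N)c(-c2nc3cc(Cl)ccc3[nH]2)c2nc(C#N)c(C#N)nc21` gives 11700 nM and holds the higher of the two actual numbers so far, while compound 1 `CN(C)CCCCn1c(N)c(-c2nc3ccccc3s2)c2nc(C#N)c(C#N)nc21` gives 5310 nM as the other. Compound 2 `CN(C)CCn1c(N)c(-c2nc3cc(Cl)ccc3[nH]2)c2nc(C#N)c(C#N)nc21` gives > 50000 nM as a limit of the assay and not a number. Compound 4 `CN(C)CCCCn1c(N)c(-c2nc3cc(Cl)ccc3[nH]2)c2nc(C#N)c(C#N)nc21` has a longer chain than compound 3, with 4-(dimethylamino)butyl in place of 3-(dimethylamino)propyl ((dimethylamino)methyl in place of dimethylamino on a saturated chain carbon, three bonds along the chain from an aromatic nitrogen). Among the compounds with values here, one measured step bears on this: the same exchange, two bonds along the chain from an aromatic nitrogen rather than three, gave an at least 4.2-fold lower number from compound 2 to compound 3 (0.63 log units; beyond the scatter) and started from a limit; its full size is unknown. Compound 1 also carries the 4-(dimethylamino)butyl chain and gives 5310 nM with it. On that basis a further, more modest fall is expected in this assay (a 2.1-fold lower number from compound 3 to compound 4 (0.33 log units; beyond the scatter)). The estimated value for compound 4 is 5500 nM with 2300 nM to 13000 nM as its expected range.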

Compound 4, half-maximal inhibitory concentration: 4730 nM
Beside the measured number, compound 4's estimate is 1.2-fold (0.07 log units) above it; measured number inside the range.
By their numbers in this assay, from the lowest: compounds 4 and 1 (each within the scatter of the next); then compound 3. At a limit, above all of these: compound 2.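

In this assay the exchange of 3-(dimethylamino)propyl for 4-(dimethylamino)butyl gives a 2.5-fold lower number from compound 3 to compound 4 (0.39 log units; beyond the scatter) with real numbers at both ends, so lengthening the chain still lowers the number at this position. The longer span gives an at least 10-fold lower number from compound 2 to compound 4 (1.02 log units; beyond the scatter) but starts from a limit, which leaves its full size unknown: the limit of > 50000 nM in this assay, at which 1 of the 4 values shown sits. With the 4-(dimethylamino)butyl chain in place, changing the aromatic group gives a 1.1-fold lower number from compound 1 to compound 4 (0.05 log units; within the scatter) and so shows no real difference.

Going by these compounds, whether a longer chain, such as 5-(dimethylamino)pentyl, lowers the number further stays open. So does the effect of a different amine at the chain end, such as piperidine or morpholine.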